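The source may hold more compounds than are shown below. What is called first, only, known or untested is meant among the compounds shown, and "the series" means these compounds.

Compound 1 `Cc1ccc(NC(=O)Nc2cccc(CNc3nccnc3Cl)c2)c(C)c1`: 9230 nM
Compound 2 `CC(C)(C)c1ccc(NC(=O)Nc2cccc(CNc3nccnc3Cl)c2)cc1`: 6010 nM
Compound 3 `O=C(Nc1cccc(CNc2nccnc2Cl)c1)Nc1cccc2ccccc12`: > 40000 nM

In a functional assay on T-24 cells (Homo sapiens) for antiproliferative activity, read by MTT assay, with a stated time of 48 h (a higher number here means a weaker inhibitor, a lower number a stronger inhibitor), compound 1 holds the highest of the two plain numbers, yet its nearest neighbour, compound 2, lies within the scatter of it, so the pair cannot be told apart. For compound 3 the result is a limit of the measurement, (the limit of > 40000 nM in this assay, at which 1 of the 3 values shown sits), and no number. Compound 4 `Cc1ccc(NC(=O)Nc2cccc(CNc3nccnc3Cl)c2)cc1Cl` is not yet measured; it differs from compound 1 in one place on the shared core, (3-chloro-4-methylphenyl in place of 2,4-dimethylphenyl on an amide-type nitrogen). Within the data shown here, no measured pair shows such a swap, so the step from compound 1 is expected to be small, probably inside the scatter, with no clear direction: a 1.3-fold lower number from compound 1 to compound 4 (0.12 log units; within the scatter). Compound 4 is accordingly estimated at 7000 nM, with a range from 2500 nM to 20000 nM.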

Compound 4, half-maximal inhibitory concentration: 7390 nM
Beside the measured number, compound 4's estimate is 1.1-fold (0.02 log units) below it, within the range that was stated.
By their numbers in this assay, from the lowest: compounds 2, 4 and 1 (each within the scatter of the next). At a limit, above all of these: compound 3.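

In this assay, among these compounds, placing 3-chloro-4-methylphenyl where 2,4-dimethylphenyl stood on the amide-type nitrogen gives a 1.2-fold lower number from compound 1 to compound 4 (0.10 log units; within the scatter) and is the only single-place change that can be read so far. At this position, then, a ring carrying a chlorine and a ring carrying only methyl groups cannot be told apart. Nothing measured here gives a reason for this result.

As far as these compounds go, whether an amine or a carboxylic acid on this phenyl ring would shift the number remains open. So does the effect of changing the chloropyrazine end of the molecule, since every compound shown keeps it.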